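Three Limits and a Fourth Compound to Come

The source may hold more compounds than are shown below. What is called first, only, known or untested is meant among the compounds shown, and "the series" means these compounds.

Compound 1 `O=C(CN1C(=O)CSC1=O)NOCc1ccccc1` is measured. In an ADME assay on RAW264.7 cells (Mus musculus) for cytotoxicity, read by neutral red uptake, with a stated time of 24 h (a higher number here means that more compound is tolerated, a lower number that less compound is tolerated), compound 1 gives > 128000 nM, which is a limit of the assay and not a number.
Compound 2 `CC(C(=O)NOCc1ccccc1)N1C(=O)CSC1=O` is measured. In this assay compound 2 gives > 128000 nM, again a limit.
Compound 3 `CCCC/C=C1\SC(=O)N(CC(=O)NOCc2ccccc2)C1=O` is measured. In this assay compound 3 gives > 128000 nM, also a limit.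

From compound 1 to compound 2 the change is methyl in place of hydrogen on a saturated chain carbon bound to an amide-type nitrogen in a ring and a carbonyl carbon. The step that the two limits leave unreadable from compound 1 to compound 2 cannot be read, since both values are limits. How the core of compound 3 differs from the core of compound 1 is not broken down here.

Compound 4 `CCCC/C=C1\SC(=O)N(C(C)C(=O)NOCc2ccccc2)C1=O` has not yet been measured. It differs from compound 3 by methyl in place of hydrogen on a saturated chain carbon bound to an amide-type nitrogen in a ring and a carbonyl carbon, the same change as from compound 1 to compound 2, at the same place.

In this assay compound 4 is expected to sit at the same limit as the others because of the limit of > 128000 nM in this assay, at which 3 of the 3 values shown sit. The step that the limit leaves unreadable from compound 3 to compound 4 is expected to be near nothing, as the earlier step of this kind could not be read. The estimate for compound 4 is 150000 nM, between 64000 nM and 320000 nM.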

Compound 4, half-maximal cytotoxic concentration: 43900 nM
Compound 4: middle estimate off by 3.4-fold (0.53 log units), on the high side, outside the stated range (below it).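

On the core of compound 3, methyl in place of hydrogen on a saturated chain carbon bound to an amide-type nitrogen in a ring and a carbonyl carbon gives, in this assay, an at least 2.9-fold lower number from compound 3 to compound 4 (0.46 log units; beyond the scatter), so with this core less compound is tolerated once the methyl is present. The same change on the core of compound 1 cannot be read, and neither can any comparison between compound 1 and compound 2, since both sit at a limit of the assay and not at a number: the limit of > 128000 nM in this assay, at which 3 of the 4 values shown sit. One readable pair therefore does not show that the change carries from one core to the other, and it gives only the smallest possible size of the step on the core of compound 3.

The compounds shown leave open whether an ethyl group, an amine or a carboxylic acid at this place would lower the number as methyl does. They also leave open whether the methyl step would hold on a core bearing a longer chain than compound 3 has.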